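Indolyl in place of methoxyphenyl: outlook for compound 4

The source may hold more compounds than are shown below. What is called first, only, known or untested is meant among the compounds shown, and "the series" means these compounds.

Measured so far:
compound 1 `CCOc1nc(-c2cc3ccccc3o2)cc(-c2ccc(Br)cc2)c1C#N` — 227000 nM
compound 2 `CCOc1nc(-c2cc3ccccc3o2)cc(-c2ccc(F)cc2)c1C#N` — 396000 nM
compound 3 `CCOc1nc(-c2cc3ccccc3o2)cc(-c2ccc(OC)cc2)c1C#N` — 204000 nM

All three numbers come from a functional assay on aorta (strain Wistar) for inhibition, with Thoracic aorta (Rattus norvegicus) as the target; a lower number here means a stronger inhibitor, a higher number a weaker inhibitor. The steps among them are a 1.7-fold higher number from compound 1 to compound 2 (0.24 log units; within the scatter), a 1.1-fold lower number from compound 1 to compound 3 (0.05 log units; within the scatter) and a 1.9-fold lower number from compound 2 to compound 3 (0.29 log units; within the scatter); compound 3 shows the lowest number of the three, but each of its steps to the others is within the scatter, so no order among compounds 1, 2 and 3 is established.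

Compound 4 `CCOc1nc(-c2cc3ccccc3o2)cc(-c2cn(C)c3ccccc23)c1C#N` is the next one to be tested. Its change from compound 3 is 1-methyl-1H-indol-3-yl in place of 4-methoxyphenyl on an aromatic carbon. For the measured compounds named here, none of the measured steps bears on this change directly: each of them swaps only the group carried by the 4-methoxyphenyl ring that now leaves, and each stayed within the scatter. Going by the values given here, the series so far gives no evidence that a change at this position moves the number beyond the scatter, and no evidence either way for exchanging the whole ring.

Compound 4 is therefore expected to land near 200000 nM. Its range is estimated at 70000 nM to 600000 nM. The expected step is a 1.0-fold lower number from compound 3 to compound 4 (0.01 log units; within the scatter), no step beyond the scatter.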

Compound 4, half-maximal inhibitory concentration: 327000 nM
Estimate against measurement, compound 4: 1.6-fold (0.21 log units) below; low and high end bracket the measured number.
By their numbers in this assay, from the lowest: compounds 3, 1, 4 and 2 (each within the scatter of the next).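

In this assay, replacing the whole ring on the carbon opposite the ring nitrogen leaves the number within the scatter (a 1.6-fold higher number from compound 3 to compound 4 (0.20 log units; within the scatter)), and the same holds for the readings against the other two rings (a 1.2-fold lower number from compound 2 to compound 4 (0.08 log units; within the scatter)) and (a 1.4-fold higher number from compound 1 to compound 4 (0.16 log units; within the scatter)). The earlier steps shown here only swapped the group carried by the phenyl ring, whereas this one shows that a two-ring 1-methyl-1H-indol-3-yl group also produces no step beyond the scatter, so compounds 1, 2, 3 and 4 remain without an established order. Nothing measured here speaks to why the number stays in this range.

As far as these compounds go, whether any group at this position can move the number beyond the scatter stays open, for instance a ring carrying an amine or a carboxylic acid. The ethoxy group is also untested in these compounds, so a longer chain there remains an open question.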